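Changing the aromatic ring on the side chain of compound 1

A few compounds are considered here, and "the series" means these few. Any claim that something is new, unique, unknown or untested is made for them only; others in the source may bear on it.

Three compounds of this series have been run in an ADME assay for permeability; on this read-out higher numbers stand for higher permeability and lower numbers for lower permeability. Compound 1 `CNC(=O)c1cc(C(=O)N[C@H]2CC[C@H](O)CC2)n([C@@H](C)c2ccc(Cl)cc2)n1` gives 180 nm/s. Compound 2 `CNC(=O)c1cc(C(=O)NC2CCOCC2)n([C@@H](C)c2ccccc2)n1` gives 270 nm/s, and compound 3 `CC[C@@H](c1ccccc1)n1nc(C(=O)NC)cc1C(=O)N[C@H]1CC[C@H](O)CC1` gives 70 nm/s. Compound 1 therefore stands second highest of the three numbers: compound 2 lies within the scatter of it, whereas compound 3 lies beyond it, since a 2.6-fold lower number from compound 1 to compound 3 (0.41 log units; beyond the scatter), a modest drop.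

Compound 4 `CNC(=O)c1cc(C(=O)N[C@H]2CC[C@H](O)CC2)n([C@@H](C)c2cccc(C(F)(F)F)c2)n1` has not yet been measured in this assay. It differs from compound 1 in one place: 3-(trifluoromethyl)phenyl in place of 4-chlorophenyl on a saturated chain carbon bound to an aromatic nitrogen and a saturated chain carbon.

For the measured compounds named here, only one measured step touches the group on that saturated chain carbon, the step from compound 1 to compound 3, and that step altered both the aromatic ring and the chain at once, so it bears on the change toward compound 4 only indirectly. Compound 2, which differs from compound 1 in more than one place, sits within the scatter of it. Neither observation points to a move beyond the scatter in either direction. Compound 4 is accordingly expected to give 200 nm/s, with a range from 90 nm/s to 420 nm/s. This expectation corresponds to a 1.1-fold higher number from compound 1 to compound 4 (0.05 log units; within the scatter), which is estimated to stay within the scatter.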

Compound 4, apparent permeability: 280 nm/s
Estimate against measurement, compound 4: 1.4-fold (0.15 log units) below; the range from low to high includes it.
By their numbers in this assay, from the lowest: compound 3; then compounds 1, 2 and 4 (each within the scatter of the next).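

In this assay, putting 3-(trifluoromethyl)phenyl in place of 4-chlorophenyl gives a 1.6-fold higher number from compound 1 to compound 4 (0.19 log units; within the scatter), and this is the first step shown that alters the aromatic ring on this saturated chain carbon while leaving the chain itself unchanged. For the compounds shown here, exchanging the one group for the other at this place thus keeps the number within the scatter of compound 1, whereas the only earlier step at this carbon (a 2.6-fold lower number from compound 1 to compound 3 (0.41 log units; beyond the scatter)) changed both ring and chain and lay beyond the scatter. No available evidence accounts for the result in either direction.

The compounds shown leave open how much of the step to compound 3 belongs to the loss of the chlorine and how much to the longer chain, since those two changes occur together in that step. They also leave open how this assay would read with a more strongly different group on this ring, such as a carboxylic acid or an amine, in place of the 4-chlorophenyl of compound 1.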